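The source may hold more compounds than are shown below. What is called first, only, known or untested is meant among the compounds shown, and "the series" means these compounds.

In a functional assay on Mahlavu cells (Homo sapiens) for antiproliferative activity, read by sulforhodamine B assay, with a stated time of 72 h (on this read-out higher numbers stand for weaker inhibition and lower numbers for stronger inhibition), compound 1 `Cc1ccccc1COc1ccc(-c2cc(CN3CCN(Cc4ccc(C(F)(F)F)cc4)CC3)no2)cc1` gives 6800 nM. Compound 2 `FC(F)(F)c1ccc(CN2CCN(Cc3cc(-c4ccc(OCc5ccc(Cl)cc5)cc4)on3)CC2)cc1` gives 3700 nM in this assay, and stands close beside compound 1, since the step of a 1.8-fold lower number from compound 1 to compound 2 (0.26 log units; within the scatter) is within the scatter. Compound 3 `N#Cc1cccc(COc2ccc(-c3cc(CN4CCN(Cc5ccc(C(F)(F)F)cc5)CC4)no3)cc2)c1` differs from compound 2 by 3-cyanophenyl in place of 4-chlorophenyl on a saturated chain carbon bound to an oxygen on an aromatic ring. Going by the values given here, the only step that bears on this place, from compound 1 to compound 2, swapped one ring for another there and stayed within the scatter, so no step beyond the scatter is expected here either, giving an expected 1.1-fold higher number from compound 2 to compound 3 (0.03 log units; within the scatter). Compound 3 is therefore estimated at 4000 nM, with a range from 1500 nM to 11000 nM.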

Compound 3, half-maximal inhibitory concentration: 10600 nM
Compound 3: the middle estimate sits 2.7-fold (0.42 log units) below what was measured, and the stated range covers the measured number.
By their numbers in this assay, from the lowest: compounds 2, 1 and 3 (each within the scatter of the next, the first and the last beyond it).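

In this assay, going by these compounds alone, swapping one ring for another on a saturated chain carbon bound to an oxygen on an aromatic ring can now make a measurable difference: 3-cyanophenyl in place of 4-chlorophenyl gives a 2.9-fold higher number from compound 2 to compound 3 (0.46 log units; beyond the scatter), the first step at this position beyond the scatter. Against 2-methylphenyl, the same 3-cyanophenyl gives a 1.6-fold higher number from compound 1 to compound 3 (0.19 log units; within the scatter), so the reading depends on which ring serves as the comparison. Nothing available explains why these rings differ. Still open, from the compounds shown here alone, is how a ring carrying an amine or a carboxylic acid would behave at this position.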